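A few compounds are considered here, and "the series" means these few. Any claim that something is new, unique, unknown or untested is made for them only; others in the source may bear on it.

Compound 2 `Cc1cccc(CSc2cc(Cl)c(C)cc2S(=O)(=O)/N=C(\N)n2nccc2-c2ccccc2)c1` was assessed in an ADME assay on HaCaT cells (Homo sapiens) for cytotoxicity, read by MTT assay, with a stated time of 72 h (a higher number here means a weaker inhibitor, a lower number a stronger inhibitor), and gave 10000 nM. Its companions share the same core: compound 1 `Cc1cc(S(=O)(=O)/N=C(\N)n2nccc2-c2ccccc2)c(SCc2ccc(Cl)cc2)cc1Cl` gave 12000 nM in this assay, and compound 3 `Cc1cc(S(=O)(=O)/N=C(\N)n2nccc2-c2ccccc2)c(SCc2cccc3ccccc23)cc1Cl` gave 11000 nM. Compound 2 thus holds the lowest of the three numbers, but every gap to the others lies within the scatter, so no order among them can be read.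

Compound 4 `Cc1cc(S(=O)(=O)/N=C(\N)n2nccc2-c2ccccc2)c(SCc2ccccc2)cc1Cl` differs from compound 2 in one place: hydrogen in place of methyl on an aromatic carbon. Cut one bond further out, the change reads (3-methylbenzyl)sulfanyl to benzylsulfanyl. Among the compounds with values here, the steps that bear on it are those altering the same aryl group bound through a saturated chain carbon to sulfur: a 1.2-fold lower number from compound 1 to compound 2 (0.08 log units; within the scatter) and a 1.1-fold higher number from compound 2 to compound 3 (0.04 log units; within the scatter). Both stayed within the scatter, even where the aryl group changed far more than here. A step of the present kind, smaller than either, is therefore expected to show nothing beyond the scatter, a 1.1-fold higher number from compound 2 to compound 4 (0.04 log units; within the scatter). Compound 4 is expected to give about 11000 nM in this assay, within a range from 6000 nM to 20000 nM.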

Compound 4, half-maximal inhibitory concentration: 18000 nM
Compound 4: middle estimate off by 1.6-fold (0.21 log units), on the low side; the measured number falls inside the stated range.
By their numbers in this assay, from the lowest: compounds 2, 3, 1 and 4 (each within the scatter of the next).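

In this assay, the bare phenyl of compound 4 gives no step beyond the scatter from any of the substituted aryl groups: a 1.8-fold higher number from compound 2 to compound 4 (0.26 log units; within the scatter), a 1.5-fold higher number from compound 1 to compound 4 (0.18 log units; within the scatter) and a 1.6-fold higher number from compound 3 to compound 4 (0.21 log units; within the scatter). These steps are larger than those among the three earlier compounds, yet none leaves the scatter, so phenyl, 3-methylphenyl, 4-chlorophenyl and naphthalen-1-yl cannot be placed in any order at this position. No measurement is available that would account for these numbers.

All four compounds carry an unbroken hydrocarbon or chloro-substituted aryl group on the chain carbon bound to sulfur. As far as these compounds go, what an amine or a carboxylic acid on that ring would give stays open, as does a longer chain between ring and sulfur, and so does whether any change here can move the number beyond the scatter.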